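Fluorophenyl position on the core amide: compound 3 to compound 4

This account rests on a few compounds, and the source may have more. Where it says the series, first, only, none or still open, it means among the compounds named here.

Measured compounds in a functional assay on NCI-H460 cells (Homo sapiens) for cytotoxicity, read by MTT assay, with a stated time of 72 h; a lower number here means a stronger inhibitor, a higher number a weaker inhibitor:
compound 1, `COc1cc2c(Oc3ccc(NC(=O)c4nn(-c5ccccc5F)c(=O)c5ccccc45)cc3F)ccnc2cc1OCCCN1CCN(C)CC1`, gives 230 nM
compound 2, `COc1cc2c(Oc3ccc(NC(=O)c4nn(-c5ccccc5)c(=O)c5ccccc45)cc3F)ccnc2cc1OCCCN1CCC(C)CC1`, gives 550 nM
compound 3, `COc1cc2c(Oc3ccc(NC(=O)c4nn(-c5cccc(F)c5)c(=O)c5ccccc45)cc3F)ccnc2cc1OCCCN1CCC(C)CC1`, gives 190 nM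

Compound 3 has the lowest number of the three in this assay. Its nearest neighbour is compound 1, which lies within the scatter of it, so no order between compound 3 and compound 1 is claimed; compound 2 lies furthest away, beyond the scatter.

The next compound, compound 4 `COc1cc2c(Oc3ccc(NC(=O)c4nn(-c5ccccc5F)c(=O)c5ccccc45)cc3F)ccnc2cc1OCCCN1CCC(C)CC1`, differs from compound 3 in one place: 2-fluorophenyl in place of 3-fluorophenyl on an aromatic nitrogen. Within the data shown here, the only measured step that touches the fluorine on this phenyl ring is a 2.9-fold lower number from compound 2 to compound 3 (0.46 log units; beyond the scatter), which put a fluorine where compound 2 had none. Among the measured compounds shown here, no measured step moves the fluorine from one ring position to another. Compound 1 already carries the 2-fluorophenyl group, but with a different amine on the side chain, and its number sits within the scatter of compound 3. Compound 4 is therefore expected to stay close to compound 3 in this assay, with a 1.3-fold higher number from compound 3 to compound 4 (0.12 log units; within the scatter), and no change beyond the scatter is expected. The estimate for compound 4 in this assay is 250 nM, in the range 120 nM to 520 nM.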

Compound 4, half-maximal inhibitory concentration: 200 nM
For compound 4 the middle estimate is 1.3-fold (0.10 log units) above the measured one, and the stated range covers the measured number.
By their numbers in this assay, from the lowest: compounds 3, 4 and 1 (each within the scatter of the next); then compound 2.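

In this assay the fluorine placement on the aromatic nitrogen's phenyl ring shows a 1.1-fold higher number from compound 3 to compound 4 (0.02 log units; within the scatter), so 2-fluorophenyl and 3-fluorophenyl cannot be told apart here. The 2-fluorophenyl group also stands clear of the plain phenyl group, with a 2.8-fold lower number from compound 2 to compound 4 (0.44 log units; beyond the scatter), so the difference from compound 2 is not tied to the 3-fluorophenyl placement alone. Compound 4 also gives a direct reading of the side-chain amine with the 2-fluorophenyl group held fixed: a 1.2-fold lower number from compound 1 to compound 4 (0.06 log units; within the scatter), which leaves 4-methylpiperidin-1-yl and 4-methylpiperazin-1-yl within the scatter of each other.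

Still open, as far as these compounds go, is how a pyridyl ring or a methoxyphenyl group would read on this aromatic nitrogen, and how a morpholine would read at the end of the side chain. No measurement on hand accounts for these numbers.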